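A few compounds are considered here, and "the series" means these few. Any claim that something is new, unique, unknown or untested is made for them only; others in the source may bear on it.

Compound 3 `O=C(CN(CC1CC1)C(=O)c1ccc(-c2ccccn2)cc1)Nc1cc(F)cc(F)c1` gives the lowest of the two numbers recorded in an assay on HEK293 cells for inhibition of sodium- and chloride-dependent glycine transporter 1 (Homo sapiens), read by scintillation proximity assay (on this read-out lower numbers stand for stronger inhibition and higher numbers for weaker inhibition), with a value of 200 nM. Compound 2 `O=C(CN(C(=O)C1CCOCC1)C1CCCCC1)Nc1cc(F)cc(F)c1` gives 5010 nM in this assay. Compound 1 `O=C(CN(Cc1ccc(Cl)cc1)C1CCCCC1)Nc1cc(F)cc(F)c1` reaches only a limit of the assay, > 25100 nM. Within the data shown here, the one step measured between two compounds that differ in a single place is an at least 5.0-fold lower number from compound 1 to compound 2 (0.69 log units; beyond the scatter), and its size rests on (the limit of > 25100 nM in this assay, at which 1 of the 3 values shown sits). Compound 4 `COCC(C)N(CC(=O)Nc1cc(F)cc(F)c1)C(=O)c1ccc(-c2ccccn2)cc1` differs from compound 3 by 1-(methoxymethyl)ethyl in place of cyclopropylmethyl on an amide-type nitrogen. Among the measured compounds shown here, no measured step changes that position, so the step from compound 1 to compound 2 gives no direct guide, and the author expects a change of only a 1.5-fold higher number from compound 3 to compound 4 (0.18 log units; within the scatter) for compound 4, within the usual scatter. Compound 4 is therefore estimated at 300 nM, with a range from 100 nM to 1000 nM.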

Compound 4, half-maximal inhibitory concentration in the sodium- and chloride-dependent glycine transporter 1 assay: 1260 nM
The estimate for compound 4 lay 4.2-fold (0.62 log units) below the measured number, and the stated range ends below it.
By their numbers in the sodium- and chloride-dependent glycine transporter 1 assay, from the lowest: compound 3; then compound 4; then compound 2. At a limit, above all of these: compound 1.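

Among these compounds, at this place on the amide-type nitrogen, 1-(methoxymethyl)ethyl in place of cyclopropylmethyl does matter in the sodium- and chloride-dependent glycine transporter 1 assay, where compound 3 gives 200 nM and compound 4 gives 1260 nM, with a 6.3-fold higher number from compound 3 to compound 4 (0.80 log units; beyond the scatter), the only measured step at this position. In a physicochemical assay for lipophilicity (on this read-out higher numbers stand for higher lipophilicity and lower numbers for lower lipophilicity), compound 3 gives 3.1 and compound 4 gives 3, and the same change gives a number 0.10 log units lower from compound 3 to compound 4 (within the scatter), so that read-out does not tell the two compounds apart, while the sodium- and chloride-dependent glycine transporter 1 assay does. The compounds shown offer no measured cause for the step.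

From the compounds shown here alone, whether the step follows the loss of the three-membered ring, the entering oxygen or the branching stays open. Going by these compounds, how a plain isopropyl group or an unbranched 2-methoxyethyl chain would read at this nitrogen remains equally open.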